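The source may report more compounds than this note shows. Statements on the series, on what has been measured and on what is new or still open speak of the compounds shown alone.

Measured in an ADME assay on HepG2 cells (Homo sapiens) for cytotoxicity, read by luminescence, with a stated time of 72 h (on this read-out lower numbers stand for an effect already at smaller amounts and higher numbers for an effect only at larger amounts of compound), each value a limit of the assay:
- compound 1 (`CCOC(=O)c1c(-c2cccc(OC(F)(F)F)c2)[nH]c2cc(OC)ccc2c1=O`) gives > 21500 nM as a limit
- compound 2 (`CCOC(=O)c1c(-c2cccc(-c3ccccc3)c2)[nH]c2cc(OC)c(F)cc2c1=O`) gives > 21500 nM as a limit
- compound 3 (`CCOC(=O)c1c(-c2cccc(OC(F)(F)F)c2)[nH]c2cc(OC)c(F)cc2c1=O`) gives > 21500 nM as a limit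

Compound 3 stands at the limit of > 21500 nM in this assay, at which 3 of the 3 values shown sit, and has no number. Compound 4 (`CCOC(=O)c1c(-c2cccc(-c3c(C)cccc3C)c2)[nH]c2cc(OC)c(F)cc2c1=O`) carries 2,6-dimethylphenyl in place of trifluoromethoxy on an aromatic carbon and otherwise matches compound 3. Among the compounds with values here, two measured steps bear on this change: a step that the two limits leave unreadable from compound 2 to compound 3 for trifluoromethoxy in place of phenyl and a step that the two limits leave unreadable from compound 1 to compound 3 for fluoro in place of hydrogen. Neither gives a readable size. The estimated step is a number no higher from compound 3 to compound 4 (the limit leaves the size open) and nothing beyond the scatter is expected in this assay on this basis. Another limit is the likeliest report. For compound 4 the expected value is 21500 nM with an estimated range of 9000 nM to 43000 nM as the expected spread.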

Compound 4, half-maximal effective concentration: > 21500 nM
Compound 4 gave a limit, no number (the forecaster's own chance of this, stated with the estimate: 80%); the middle value lies on the limit itself.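

Compound 4 gives a limit, as do compound 3 and compound 2, so no step to compound 4 can be read: the limit of > 21500 nM in this assay, at which 4 of the 4 values shown sit.

The compounds shown leave open where any of them reaches a half-maximal effect, and whether these changes shift it.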